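From a hydroxypropyl group to an ethylsulfonyl group

The source may hold more compounds than are shown below. What is called first, only, known or untested is meant among the compounds shown, and "the series" means these compounds.

For the measured compounds named here, in an ADME assay on MT4 cells (Homo sapiens) for cytotoxicity, read by MTT assay, with a stated time of 5 days (a higher number here means that more compound is tolerated, a lower number that less compound is tolerated), compound 2 `CC(O)CN(c1ccnc(Nc2ccc(C#N)cc2)n1)c1c(F)cc(-c2ccc(C#N)cc2)cc1F` gives 9800 nM, the lower of the two numbers measured so far; compound 1 `CC(C)N(c1ccnc(Nc2ccc(C#N)cc2)n1)c1c(F)cc(-c2ccc(C#N)cc2)cc1F` gives 172000 nM. Going by the values given here, the only measured step, an 18-fold lower number from compound 1 to compound 2 (1.24 log units; beyond the scatter), changed the group on the same nitrogen. Compound 3 `CCS(=O)(=O)N(c1ccnc(Nc2ccc(C#N)cc2)n1)c1c(F)cc(-c2ccc(C#N)cc2)cc1F` differs from compound 2 by ethylsulfonyl in place of 2-hydroxypropyl on a nitrogen on an aromatic ring. Among the compounds with values here, no measured step involves an ethylsulfonyl group, so the direction is uncertain, and the expected step is a 3.1-fold higher number from compound 2 to compound 3 (0.49 log units; beyond the scatter). Compound 3 is estimated at 30000 nM, with a range from 6000 nM to 150000 nM.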

Compound 3, half-maximal cytotoxic concentration: > 125000 nM
Compound 3: no number, only a limit; the forecaster's own chance of this, stated with the estimate: 10%; at least 4.1-fold (0.61 log units) between middle value and limit.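

Compound 3 gives only a limit of the assay, not a number: the limit of > 125000 nM in this assay, at which 1 of the 3 values shown sits.

Even so, placing ethylsulfonyl on this nitrogen gives an at least 12-fold higher number from compound 2 to compound 3 (1.10 log units; beyond the scatter), so this position can move the number up as well as down, which the earlier step alone did not show. From the compounds shown here alone, the step between compound 1 and compound 3 cannot be read, so the order of those two stays open. Also open, going by these compounds, is whether an amine or a carboxylic acid on this nitrogen would sit closer to compound 2 or to compound 1.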